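Working notes: methoxy in place of bromo

A few compounds are considered here, and "the series" means these few. Any claim that something is new, unique, unknown or untested is made for them only; others in the source may bear on it.

In an ADME assay on MDCK cells (Canis lupus familiaris) for cytotoxicity, read by MTT assay, with a stated time of 24 h (on this read-out higher numbers stand for lower toxicity in this test and lower numbers for higher toxicity in this test), compound 2 (`N#CCCN(Cc1cccs1)S(=O)(=O)c1ccc(Br)cc1`) gives > 173000 nM, which is a limit and not a number. Compound 1 (`N#CCCN(Cc1cccs1)S(=O)(=O)c1cccc(F)c1`) gives > 205000 nM, likewise a limit. Compound 3 (`COc1ccc(S(=O)(=O)N(CCC#N)Cc2cccs2)cc1`) differs from compound 2 as follows: methoxy in place of bromo on an aromatic carbon. Among the compounds with values here, the one measured step, a step that the two limits leave unreadable from compound 1 to compound 2, offers no size to carry over, and it involves a different change. No step beyond the scatter is therefore expected in this assay. The estimated step is a step that the limit leaves unreadable from compound 2 to compound 3. For compound 3 the expected value is 198000 nM, with an estimated range of 120000 nM to 300000 nM.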

Compound 3, half-maximal cytotoxic concentration: > 198000 nM
Compound 3: no number, only a limit; the forecaster's own chance of this, stated with the estimate: 85%; the middle value sits exactly at the limit.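

No step can be read from compound 2 to compound 3 in this assay: both values are limits and not numbers. The compounds shown leave open what the actual half-maximal cytotoxic concentration of compound 1, compound 2 or compound 3 is.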